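Shortening the imidazole side chain to a direct phenyl

This account rests on a few compounds, and the source may have more. Where it says the series, first, only, none or still open, it means among the compounds named here.

Compound 2 `O=C(O)c1ccccc1-c1ccc(CCc2ncc(CCc3ccccc3)[nH]2)cc1` shows the highest number of the two measured in an in vitro functional assay on cells for agonist activity at Bombesin receptor subtype-3 (Homo sapiens), read by luminescence and calcium flux (a higher number here means that more compound is needed for the effect, a lower number that less compound is needed), giving 1320 nM; its nearest neighbour, compound 1 `O=C(O)c1ccccc1-c1ccc(CCc2ncc(Cc3cccc(F)c3)[nH]2)cc1`, gives 159 nM in this assay. Going by the values given here, the only measured step, an 8.3-fold higher number from compound 1 to compound 2 (0.92 log units; beyond the scatter), concerns the group on the saturated chain carbon, not the chain itself. Compound 3 `O=C(O)c1ccccc1-c1ccc(CCc2ncc(-c3ccccc3)[nH]2)cc1` differs from compound 2 by phenyl in place of phenethyl on an aromatic carbon. Among the compounds with values here, no measured step covers removal of the two chain carbons, so the direction of a 1.5-fold higher number from compound 2 to compound 3 (0.18 log units; within the scatter) is expected only with wide uncertainty; the measured step shows this region tolerates change with sizeable effect, and the shortened chain is expected to fall somewhere around the value of compound 2 rather than to recover the number of compound 1. Compound 3 is therefore estimated at 2000 nM in this assay, with a range from 400 nM to 10000 nM.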

Compound 3, half-maximal effective concentration: 4950 nM
The estimate for compound 3 lay 2.5-fold (0.39 log units) below the measured number; the range from low to high includes it.
By their numbers in this assay, from the lowest: compound 1; then compound 2; then compound 3.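

Phenyl in place of phenethyl gives a 3.8-fold higher number from compound 2 to compound 3 (0.57 log units; beyond the scatter) in this assay, so at this aromatic carbon, shortening the chain while keeping the phenyl ring moves the number upward. Phenyl in place of 3-fluorobenzyl gives a 31-fold higher number from compound 1 to compound 3 (1.49 log units; beyond the scatter), and among these three compounds a saturated chain carbon between this position and the outer aromatic ring is present in compound 1 and compound 2, which have the two lower numbers, and absent from compound 3. No evidence on the cause of these steps is at hand.

As far as these compounds go, how much of the lower number of compound 1 comes from the fluorine and how much from the shorter link stays open, and plain benzyl at this position would separate the two. Also open, from the compounds shown here alone, are a longer chain such as 3-phenylpropyl and an amine within the chain.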